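The source may report more compounds than this note shows. Statements on the series, on what has been measured and on what is new or still open speak of the compounds shown alone.

In an ADME assay on MT4 cells (Homo sapiens) for cytotoxicity, read by MTT assay (a lower number here means that less compound is tolerated, a higher number that more compound is tolerated), compound 1 `Cc1cccc(C(=O)N(C(=S)OCCN2C(=O)c3ccccc3C2=O)c2ccc(Cl)cc2)c1` gives 58000 nM, compound 2 `O=C1c2ccccc2C(=O)N1CCOC(=S)N(C(=O)c1cccc(F)c1F)c1ccc(Cl)cc1` gives 58000 nM and compound 3 `O=C1c2ccccc2C(=O)N1CCOC(=S)N(C(=O)c1cccc(Cl)c1Cl)c1ccc(Cl)cc1` gives 54000 nM. Compound 3 thus stands within the scatter of both other compounds. Compound 4 `O=C1c2ccccc2C(=O)N1CCOC(=S)N(C(=O)c1cc(Cl)cc(Cl)c1)c1ccc(Cl)cc1` differs from it as follows: 3,5-dichlorophenyl in place of 2,3-dichlorophenyl on a carbonyl carbon. The measured steps at this same place are no change at the digits printed from compound 1 to compound 2 (within the scatter), a 1.1-fold lower number from compound 1 to compound 3 (0.03 log units; within the scatter) and a 1.1-fold lower number from compound 2 to compound 3 (0.03 log units; within the scatter), all within the scatter. None of them involves the 3,5-dichlorophenyl group, so the read-across is indirect. No step beyond the scatter is expected in this assay. For compound 4 the estimated value is 52000 nM, with an expected range of 25000 nM to 100000 nM. The expected step is a 1.0-fold lower number from compound 3 to compound 4 (0.02 log units; within the scatter).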

Compound 4, half-maximal cytotoxic concentration: 32000 nM
Beside the measured number, compound 4's estimate is 1.6-fold (0.21 log units) above it, and the stated range covers the measured number.
By their numbers in this assay, from the lowest: compounds 4, 3, 1 and 2 (each within the scatter of the next).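

In this assay the 3,5-dichlorophenyl group gives a 1.7-fold lower number from compound 3 to compound 4 (0.23 log units; within the scatter) when it replaces 2,3-dichlorophenyl on a carbonyl carbon, a 1.8-fold lower number from compound 2 to compound 4 (0.26 log units; within the scatter) when it replaces 2,3-difluorophenyl and a 1.8-fold lower number from compound 1 to compound 4 (0.26 log units; within the scatter) when it replaces 3-methylphenyl. This position therefore still shows no step beyond the scatter, even with the same atoms joined differently in the aryl group. Nothing available bears on a cause for these numbers. Going by these compounds, whether an aminophenyl or carboxyphenyl group on this carbonyl carbon would give a step beyond the scatter stays open.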